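The source may report more compounds than this note shows. Statements on the series, on what has been measured and on what is new or still open speak of the compounds shown alone.

Of the compounds shown here, two have been measured in a functional assay on 786-0 cells (Homo sapiens) for inhibition; on this read-out higher numbers stand for weaker inhibition of growth and lower numbers for stronger inhibition of growth. Compound 1 `COc1cc(/C=C/C(=O)c2cccc(-n3cc(-c4ccccc4)[nH]c3=O)c2)cc(OC)c1OC` carries a phenyl group on the shared core, and in this assay compound 1 gives 1380 nM. Compound 2 `O=C(/C=C/c1cccc(O)c1)c1cccc(-n2cc(-c3ccc(Cl)cc3)[nH]c2=O)c1` carries a 4-chlorophenyl group in the same position and a different pattern on its other aromatic ring; in this assay compound 2 gives 1570 nM. Compound 1 stands at one end of these two numbers, yet its gap to compound 2 lies within the scatter, so the two compounds cannot be ranked on these data.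

Compound 3 `COc1cc(/C=C/C(=O)c2cccc(-n3cc(-c4ccc(Cl)cc4)[nH]c3=O)c2)cc(OC)c1OC` has not been measured. It differs from compound 1 in one place: chloro in place of hydrogen on an aromatic carbon. Going by the values given here, no measured pair shows this change on its own, so the size of the step is not known from experiment. Since compound 2, which carries the same 4-chlorophenyl group, gives 1570 nM in this assay, close to compound 1, there is little ground to expect a step beyond the scatter. Compound 3 is therefore expected to give about 1200 nM in this assay, with a range from 500 nM to 2900 nM. The step of a 1.2-fold lower number from compound 1 to compound 3 (0.06 log units; within the scatter) is expected to be none beyond the scatter.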

Compound 3, concentration for 50% growth inhibition: 2140 nM
For compound 3 the middle estimate is 1.8-fold (0.25 log units) below the measured one, and the stated range covers the measured number.
By their numbers in this assay, from the lowest: compounds 1, 2 and 3 (each within the scatter of the next).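

Going by these compounds alone, the pair of compound 1 and compound 3 is the first to isolate one change in this assay: chloro in place of hydrogen on an aromatic carbon, para to a large group, which turns phenyl into 4-chlorophenyl. This change gives a 1.6-fold higher number from compound 1 to compound 3 (0.19 log units; within the scatter), so at this position and on this core, the read-out does not distinguish the chloro group from hydrogen, and a single added chlorine atom is accepted without a step larger than the differences expected between repeated measurements. Nothing available here bears on why the chloro group leaves the number within that scatter.

The compounds shown leave open whether a group of another kind at the same position, such as an amine or a carboxylic acid, would produce a step beyond the scatter, and whether chloro on a different carbon of this ring would match the result seen here. They also leave open whether the phenyl to 4-chlorophenyl change would give a similar step with a different pattern on the other aromatic ring, as this single pair covers only one such pattern.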